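Swapping the Sulfonylphenyl for Thiophene: Expected Half-Life

The source may hold more compounds than are shown below. What is called first, only, known or untested is meant among the compounds shown, and "the series" means these compounds.

Of the compounds shown here, three that share one core have been measured in an ADME assay on microsomes from liver (Rattus norvegicus) for metabolic stability, read by LC-MS, tested at 1 mM; on this read-out lower numbers stand for a shorter-lived compound and higher numbers for a longer-lived compound. Compound 1 `CC(C)S(=O)(=O)c1ccc(-c2c[nH]c3c(=O)n(Cc4cc(F)ccc4C#N)c(N4CCC[C@@H](N)C4)nc23)cc1` gives only a limit of the assay, > 3.33 h. Compound 2 `CS(=O)(=O)c1ccccc1-c1c[nH]c2c(=O)n(Cc3cc(F)ccc3C#N)c(N3CCC[C@@H](N)C3)nc12` gives 3.29 h, and compound 3 `CS(=O)(=O)c1ccc(-c2c[nH]c3c(=O)n(Cc4cc(F)ccc4C#N)c(N4CCC[C@@H](N)C4)nc23)c(F)c1` gives 1.59 h. Among the two plain numbers, compound 2 stands highest; the step of a 2.1-fold lower number from compound 2 to compound 3 (0.32 log units; beyond the scatter) lies beyond the scatter, whereas an at least 1.0-fold lower number from compound 1 to compound 2 (0.00 log units; that floor lies within the scatter) does not. Compound 4 `N#Cc1ccc(F)cc1Cn1c(N2CCC[C@@H](N)C2)nc2c(-c3ccsc3)c[nH]c2c1=O` has not yet been measured. It differs from compound 2 in one place: thiophen-3-yl in place of 2-(methylsulfonyl)phenyl on an aromatic carbon. For the measured compounds named here, none of the measured steps replaces the sulfonyl-bearing ring with a different ring type; each only alters the groups on that ring, and the largest of them, an at least 2.0-fold lower number from compound 1 to compound 3 (0.32 log units; beyond the scatter), is modest. With no closer guide, a change at this position of similar or somewhat larger size, leaning downward, is the most defensible expectation. Compound 4 is therefore expected to give about 1.8 h in this assay, within an estimated range of 0.7 h to 4 h, which amounts to an expected step of a 1.8-fold lower number from compound 2 to compound 4 (0.26 log units; within the scatter).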

Compound 4, half-life: 0.783 h
Compound 4: the middle estimate sits 2.3-fold (0.36 log units) above what was measured; measured number inside the range.
By their numbers in this assay, from the lowest: compound 4; then compound 3; then compound 2. At a limit, above all of these: compound 1.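

Earlier compounds only varied the groups on a sulfonyl-bearing phenyl ring, whereas replacing that ring outright with thiophen-3-yl gives a 4.2-fold lower number from compound 2 to compound 4 (0.62 log units; beyond the scatter) in this assay, a larger step than any fully measured one among them. Even the shortest-lived of the sulfonyl-bearing compounds stays ahead of the thiophene, with a 2.0-fold lower number from compound 3 to compound 4 (0.31 log units; beyond the scatter), so at this position all three sulfonyl-bearing rings outlast thiophen-3-yl. The remaining step, an at least 4.2-fold lower number from compound 1 to compound 4 (0.62 log units; beyond the scatter), is only a floor, set by a limit of the assay: the limit of > 3.33 h in this assay, at which 1 of the 4 values shown sits.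

The compounds shown do not separate the loss of the sulfonyl group from the change of ring, as the two happen together in this swap. A plain phenyl ring, or a thiophen-3-yl carrying a methylsulfonyl group, would tell these two changes apart.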